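A few compounds are considered here, and "the series" means these few. Any claim that something is new, unique, unknown or untested is made for them only; others in the source may bear on it.

- Compound 1 `COc1ccc(/C=C(\C(=O)c2ccc(Br)cc2)S(=O)(=O)c2ccc(Br)cc2)cc1`: 25000 nM
- Compound 2 `O=C(/C(=C\c1ccc(Br)c(O)c1)S(=O)(=O)c1ccc(Br)cc1)c1ccc(Br)cc1`: 50000 nM
- Compound 3 `O=C(/C(=C\c1csc([N+](=O)[O-])c1)S(=O)(=O)c1ccc(Br)cc1)c1ccc(Br)cc1`: 1000 nM

In a functional assay on DU-145 cells (Homo sapiens) for inhibition, read by trypan blue exclusion, with a stated time of 96 h (on this read-out lower numbers stand for stronger inhibition of growth and higher numbers for weaker inhibition of growth), compound 3 has the lowest number of the three, at 1000 nM. Compound 4 `COc1ccc(/C=C(\C(=O)c2ccc(Br)cc2)S(=O)(=O)c2ccc(Br)cc2)c(F)c1` replaces its 5-nitrothiophen-3-yl with 2-fluoro-4-methoxyphenyl: 2-fluoro-4-methoxyphenyl in place of 5-nitrothiophen-3-yl on a double-bonded chain carbon bound to a double-bonded chain carbon. Going by the values given here, two measured steps bear on this change, and both are large: a 25-fold lower number from compound 1 to compound 3 (1.40 log units; beyond the scatter) and a 50-fold lower number from compound 2 to compound 3 (1.70 log units; beyond the scatter). Each brings in the 5-nitrothiophen-3-yl group that compound 4 gives up. The two phenyl groups compared in a 2.0-fold higher number from compound 1 to compound 2 (0.30 log units; within the scatter) differ little by comparison. Among the compounds with values here, no measured compound carries the 2-fluoro-4-methoxyphenyl group, so the reverse of those large steps is only an expectation. A large move to a higher number is expected, estimated as a 15-fold higher number from compound 3 to compound 4 (1.18 log units; beyond the scatter). Compound 4 is estimated at 15000 nM, with an expected range of 4000 nM to 50000 nM.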

Compound 4, concentration for 50% growth inhibition: 10000 nM
Estimate against measurement, compound 4: 1.5-fold (0.18 log units) above, and the stated range covers the measured number.
By their numbers in this assay, from the lowest: compound 3; then compound 4; then compounds 1 and 2 (each within the scatter of the next).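

In this assay, a 2.5-fold lower number from compound 1 to compound 4 (0.40 log units; beyond the scatter) shows that fluoro in place of hydrogen on an aromatic carbon is enough to shift the number beyond the scatter, a smaller change than any earlier step at this position. Even so, the 2-fluoro-4-methoxyphenyl group does not match the 5-nitrothiophen-3-yl group, with a 10-fold higher number from compound 3 to compound 4 (1.00 log units; beyond the scatter), though it gives a lower number than 4-bromo-3-hydroxyphenyl, with a 5.0-fold lower number from compound 2 to compound 4 (0.70 log units; beyond the scatter). Nothing available explains these shifts. The compounds shown leave open whether a thiophen-3-yl group without the nitro group would keep the low number of compound 3. They also leave open how an amine or a carboxylic acid on the phenyl group would compare.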